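Series notes: acyl change on the urea of compound 1

The source may report more compounds than this note shows. Statements on the series, on what has been measured and on what is new or still open speak of the compounds shown alone.

Compound 1 `CN(C(=O)NC(=O)c1cccc(C(F)(F)F)c1)c1nc(C(F)(F)F)c(C(=O)N/N=C/c2ccc(C(F)(F)F)cc2)s1` gives 6.2 ug/mL in a functional assay on A549 cells (Homo sapiens) for inhibition, read by MTT assay, with a stated time of 72 h; on this read-out lower numbers stand for stronger inhibition and higher numbers for weaker inhibition. Compound 2 `CN(C(=O)NC(=O)c1cccc(C(F)(F)F)c1)c1nc(C(F)(F)F)c(C(=O)N/N=C/c2ccccc2C(F)(F)F)s1` gives 12.1 ug/mL, and a 2.0-fold higher number from compound 1 to compound 2 (0.29 log units; within the scatter) is within the scatter, so the two stand together. Compound 3 `CN(C(=O)NC(=O)c1ccccc1F)c1nc(C(F)(F)F)c(C(=O)N/N=C/c2ccc(C(F)(F)F)cc2)s1` carries 2-fluorophenyl in place of 3-(trifluoromethyl)phenyl on a carbonyl carbon. For the measured compounds named here, the only measured step alters the aryl on a carbon with a double bond to nitrogen, not the aryl on the carbonyl carbon, so no measured step bears on this change. With no guide, no step beyond the scatter is expected, and a 1.3-fold higher number from compound 1 to compound 3 (0.11 log units; within the scatter) is the working estimate. Compound 3 is therefore expected at 8 ug/mL, within 3 ug/mL to 25 ug/mL.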

Compound 3, half-maximal inhibitory concentration: 5.68 ug/mL
Compound 3: middle estimate off by 1.4-fold (0.15 log units), on the high side; the measured number falls inside the stated range.
By their numbers in this assay, from the lowest: compounds 3, 1 and 2 (each within the scatter of the next, the first and the last beyond it).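

In this assay, for the compounds shown here, the first reading at the aryl on the carbonyl carbon, 2-fluorophenyl in place of 3-(trifluoromethyl)phenyl gives a 1.1-fold lower number from compound 1 to compound 3 (0.04 log units; within the scatter). This position therefore tolerates this exchange, and the two aryl groups cannot be told apart on this read-out. No measured evidence accounts for this result.

On these data alone, whether a non-aromatic group such as cyclohexyl, or an aryl carrying an amine, would hold the read-out on this carbonyl carbon remains open. Also open, as far as these compounds go, is whether 2-fluorophenyl would read the same alongside the 2-(trifluoromethyl)phenyl of compound 2.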